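The source may hold more compounds than are shown below. What is called first, only, known or untested is meant among the compounds shown, and "the series" means these compounds.

Compound 1 `O=C(/C=C/CCCCCCc1ccccc1)N[C@H]1CC[C@H](O)CC1`: > 100000 nM
Compound 2 `O=C(CCCCCCCCCCc1ccccc1)N1CCCCC1`: > 100000 nM
Compound 3 `O=C(CCCOCCCCc1ccccc1)N1CCCCC1`: > 100000 nM

These results all come from a functional assay on PANC-1 cells (Homo sapiens) for cytotoxicity, read by WST assay, with a stated time of 24 h; on this read-out lower numbers stand for stronger inhibition and higher numbers for weaker inhibition. Compound 2 stands at > 100000 nM, which is a limit of the assay and not a number. It cannot be ranked against the other two compounds, since the data show (the limit of > 100000 nM in this assay, at which 3 of the 3 values shown sit).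

Compound 4 `N#Cc1ccc(CCCCCCCCC(=O)N2CCCCC2)cc1` has not yet been measured. In compound 4, 4-cyanophenyl stands in place of the phenethyl of compound 2, on a saturated chain carbon, eight bonds along the chain from a carbonyl carbon: 4-cyanophenyl in place of phenethyl on a saturated chain carbon, eight bonds along the chain from a carbonyl carbon.

For the measured compounds named here, no pair of measured compounds differs in just one place, so no measured step can serve as a guide to the size of this change. Going by the values given here, the only guide is the shared result: the three measured compounds differ in structure, yet the data show (the limit of > 100000 nM in this assay, at which 3 of the 3 values shown sit). No change beyond the usual scatter is therefore expected in this assay, in either direction. The expected size of the step of a number no higher from compound 2 to compound 4 (the limit leaves the size open) is correspondingly small.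

Compound 4 is estimated at 100000 nM, with an expected range of 40000 nM to 200000 nM, and the result will most likely be reported only as a limit.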

Compound 4, half-maximal inhibitory concentration: > 100000 nM
Compound 4: no number, only a limit; the forecaster's own chance of this, stated with the estimate: 75%; the middle value sits exactly at the limit.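

In this assay compound 4 gives > 100000 nM, which is a limit of the assay and not a number. Compound 2 also sits at a limit, so no step can be read between compound 2 and compound 4: the limit of > 100000 nM in this assay, at which 4 of the 4 values shown sit.

The compounds shown leave open how strongly any of them acts in this assay, and how 4-cyanophenyl compares with phenethyl.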